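Cytotoxicity in the shared core series: toward compound 4

The source may report more compounds than this note shows. Statements on the series, on what has been measured and on what is new or still open speak of the compounds shown alone.

Measured compounds:
Compound 1 `Cc1ccc(-c2ccc3[nH]c(=O)nc(-c4ccccc4)c3c2)cn1` gives > 50000 nM in an ADME assay on THP-1 cells (Homo sapiens) for cytotoxicity, read by MTT assay, with a stated time of 72 h (a lower number here means that less compound is needed, a higher number that more compound is needed for the effect), a limit of the assay.
Compound 2 `O=c1nc(-c2ccccc2)c2cc(-c3ccccc3)ccc2[nH]1` gives > 50000 nM in this assay, a limit of the assay.
Compound 3 `O=c1nc(-c2ccccc2)c2cc(-c3cccc(F)c3)ccc2[nH]1` gives > 50000 nM in this assay, a limit of the assay.

Compound 3 stands only at a limit in this assay; the two other values shown are limits too, all at the limit of > 50000 nM in this assay, at which 3 of the 3 values shown sit. The steps between the measured compounds are therefore unreadable: a step that the two limits leave unreadable from compound 2 to compound 3, a step that the two limits leave unreadable from compound 1 to compound 3, and a step that the two limits leave unreadable from compound 1 to compound 2.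

The next compound, compound 4 `CNC(=O)c1cccc(-c2ccc3[nH]c(=O)nc(-c4ccccc4)c3c2)c1`, differs from compound 3 by methylcarbamoyl in place of fluoro on an aromatic carbon. The step bearing most directly on it, from the same position, is a step that the two limits leave unreadable from compound 2 to compound 3, and the step from a different aryl group, a step that the two limits leave unreadable from compound 1 to compound 3, is likewise unreadable. With every value in the series sitting at the limit, no size or direction can be taken from the measured steps, and the expectation for a number no higher from compound 3 to compound 4 (the limit leaves the size open) is no readable step. Compound 4 is expected to give about 50000 nM in this assay, within 20000 nM to 100000 nM, most likely reported as a limit.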

Compound 4, half-maximal effective concentration: > 50000 nM
Compound 4: a limit, no number; the forecaster's own chance of this, stated with the estimate: 85%; the middle value sits exactly at the limit.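

No new step can be read for compound 4 against compound 2 or compound 3, since all of them sit at a limit of the assay: the limit of > 50000 nM in this assay, at which 4 of the 4 values shown sit.

The compounds shown leave open where any of their true values lies, and which change on the shared core would give a measurable number in this assay.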